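Adding a Methyl to the Core of Compound 1

The source may hold more compounds than are shown below. What is called first, only, known or untested is meant among the compounds shown, and "the series" means these compounds.

Of the compounds shown here, three of this set have been measured in a functional assay for inhibition, with Homo sapiens as the target; a lower number here means a stronger inhibitor, a higher number a weaker inhibitor.

Compound 1, `CCCc1nc(C)c2cnn(CC)c(=O)n12`: > 48000 nM
Compound 2, `CCCc1nc(C)c2cnn(CC(=O)OCC)c(=O)n12`: > 48000 nM
Compound 3, `CCc1nc(C)c2cnn(CC)c(=O)n12`: 75600 nM

The value of compound 1 is a limit of the assay, not a number, so compound 1 stands only at the edge of what the assay can report. The value of compound 2 is likewise a limit. Compound 3 gives a number, and it sits close to that edge. Accordingly, a step that the two limits leave unreadable from compound 1 to compound 2 and a step that the limit leaves unreadable from compound 1 to compound 3; the limit of > 48000 nM in this assay, at which 2 of the 3 values shown sit, is the reason that neither step can be read.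

Compound 4, `CCCc1nc(C)c2c(C)nn(CC)c(=O)n12`, differs from compound 1 by methyl in place of hydrogen on an aromatic carbon. Within the data shown here, none of the measured steps touches this aromatic carbon of the six-membered aromatic ring with 3 nitrogen; the two steps that are known both start from compound 1 and are unreadable. No direction can therefore be expected beyond the scatter. Compound 4 is expected to give 60000 nM, between 20000 nM and 200000 nM, and most likely to be reported again as a limit. This corresponds to an expected step that the limit leaves unreadable from compound 1 to compound 4.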

Compound 4, half-maximal inhibitory concentration: > 48000 nM
Compound 4: a limit, no number (the forecaster's own chance of this, stated with the estimate: 70%); the middle value lies beyond the limit too.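

In this assay compound 4 gives > 48000 nM as a limit and not a number. Among these compounds, compound 1 also stands at a limit, so no step between the two can be read: the limit of > 48000 nM in this assay, at which 3 of the 4 values shown sit. Going by these compounds, whether methyl in place of hydrogen on this aromatic carbon changes inhibition at all remains open.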